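This account rests on a few compounds, and the source may have more. Where it says the series, first, only, none or still open, it means among the compounds named here.

Measured so far: compound 1 `O=C(O)[C@H]1NCC=C[C@@H]1O`, 25%; compound 2 `O=C(O)[C@H]1NC[C@H](O)[C@H](O)[C@H]1O`, 21%; compound 3 `O=C(O)[C@@H]1NC[C@@H](O)[C@H](O)[C@@H]1O`, 10%.

In an assay for inhibition of alpha-N-acetylgalactosaminidase (Gallus gallus), tested at 1000 uM (a lower number here means less inhibition, a higher number more inhibition at the concentration tested (going by the name of the read-out)), compound 3 stands lowest of the three, with compound 2 the nearest and compound 1 the furthest above it. The next step goes to compound 4 `O=C(O)[C@@H]1NC[C@H](O)[C@H](O)[C@H]1O`: the two compounds have the same atoms and bonds and differ only in configuration as drawn: 2 of 4 stereo elements differ; a stereocentre at a saturated ring carbon is drawn R in compound 3 and S in compound 4; a stereocentre at a saturated ring carbon is drawn R in compound 3 and S in compound 4. For the measured compounds named here, the only measured step that bears on a change of configuration alone is a number 11 percentage points lower from compound 2 to compound 3 (beyond the scatter), a modest drop explained only by the fact that (the fact that compounds 2 and 3 differ only in the configuration as drawn). Compound 4 reverses part of that change, so some recovery toward compound 2 is plausible, but the direction is not secured by one step. Compound 4 is therefore expected to show a number 7 percentage points higher from compound 3 to compound 4 (within the scatter) in this assay, a modest rise, landing at an estimated 17%, between 5% and 32%.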

Compound 4, a percentage reported as inhibition, at one concentration (the size of the read-out at that concentration, not a potency): 4.4%
Compound 4: the middle estimate sits 12.6 percentage points above what was measured; the measured number lies below the stated range.
By their numbers in this assay, from the lowest: compounds 4 and 3 (each within the scatter of the next); then compounds 2 and 1 (each within the scatter of the next).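

In this assay, inverting one stereocentre at a saturated ring carbon is enough for a number 16.6 percentage points lower from compound 2 to compound 4 (beyond the scatter), so a drop beyond the scatter does not require the three inversions of the earlier step. The two stereocentres that still separate the other pair add little, with a number 5.6 percentage points lower from compound 3 to compound 4 (within the scatter). Configuration alone carries the larger step: the fact that compounds 2 and 4 differ only in the configuration as drawn

Which of the other stereocentres matter when inverted singly stays open. So does whether a hydroxymethyl group in place of the carboxylic acid would show the same sensitivity to configuration.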